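Methylation of a phenolic hydroxyl in a pyrazole urea series

The compounds below may be only part of what the source reports. "The series", "measured", "known", "first", "only" and "open" are said of these compounds alone.

Measured compounds:
compound 1, `O=C(Nc1cccc(-n2cc(-c3ccncc3)c(-c3cc(O)cc(Cl)c3)n2)c1)Nc1ccc(Cl)c(C(F)(F)F)c1`, 105%
compound 2, `O=C(Nc1cccc(-n2cc(-c3ccncc3)c(-c3cc(O)cc(Cl)c3)n2)c1)Nc1ccc(Cl)c(Cl)c1`, 85%
compound 3, `COc1cc(Cl)cc(-c2nn(-c3cccc(NC(=O)Nc4cc(C(F)(F)F)cc(C(F)(F)F)c4)c3)cc2-c2ccncc2)c1`, 90%

Among the measured compounds shown here, in a functional assay on MDA-MB-231 cells (Homo sapiens) for inhibition, read by sulforhodamine B assay, with a stated time of 48 h, tested at 0.1 uM (a lower number here means a stronger effect, a higher number a weaker effect of the compound at the concentration tested), compound 2 gives the lowest of the three numbers; compound 3 sits within the scatter of it, and compound 1 lies beyond the scatter above it, the step of a number 20 percentage points lower from compound 1 to compound 2 (beyond the scatter) being the only single-point change measured. Compound 4, `COc1cc(Cl)cc(-c2nn(-c3cccc(NC(=O)Nc4ccc(Cl)c(Cl)c4)c3)cc2-c2ccncc2)c1`, differs from compound 2 by methyl in place of hydrogen on an oxygen on an aromatic ring. For the measured compounds named here, no measured step touches this change; compounds 1 and 3 differ in more than one place, so their values only show that both sit high. The estimate for compound 4 therefore rests on compound 2 alone, with an expected step of a number 3 percentage points higher from compound 2 to compound 4 (within the scatter), within the scatter. Compound 4 is expected to give 88%, between 75% and 102%.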

Compound 4, a percentage reported as activity, at one concentration (the size of the read-out at that concentration, not a potency): 96%
Compound 4: the middle estimate sits 8 percentage points below what was measured; the measured number falls inside the stated range.
By their numbers in this assay, from the lowest: compounds 2, 3, 4 and 1 (each within the scatter of the next, the first and the last beyond it).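

In this assay, among the compounds shown here, the change from 3-chloro-5-hydroxyphenyl to 3-chloro-5-methoxyphenyl gives the first direct reading at this oxygen, with a number 11 percentage points higher from compound 2 to compound 4 (beyond the scatter) at the concentration tested. Methyl in place of hydrogen here therefore weakens the effect in this one pair, although a single pair cannot show whether this holds more widely. Nothing available explains the step.

As far as these compounds go, whether the same change gives a similar step with the other urea substituents remains open. So does how ethoxy or an amine at this position would read.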